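This account rests on a few compounds, and the source may have more. Where it says the series, first, only, none or still open, it means among the compounds named here.

Values in an ADME assay on H9 cells (Homo sapiens) for cytotoxicity, read by XTT assay, with a stated time of 6 days (on this read-out higher numbers stand for lower toxicity in this test and lower numbers for higher toxicity in this test), so far:
compound 1 (`Cc1cc(C=O)cc(C)c1Oc1ccc([N+](=O)[O-])c(Nc2ccc(C#N)cc2)c1`): 14200 nM
compound 2 (`COc1ccc(Nc2cc(Oc3c(C)cc(C)cc3C)c([N+](=O)[O-])cc2[N+](=O)[O-])cc1`): > 59100 nM

Among the compounds with values here, compound 1 holds the only true number so far. Compound 2 reads > 59100 nM, and this is a limit of the assay, not a number.

Next is compound 3 (`Cc1cc(C)c(Oc2ccc([N+](=O)[O-])c(Nc3ccc(C#N)cc3)c2)c(C)c1`), not yet measured. Relative to compound 1 it has methyl in place of formyl on an aromatic carbon, meta to two methyl groups and para to a large group (methyl in place of formyl on an aromatic carbon).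

Within the data shown here, no measured step gives a guide to this change, so the expectation for this assay is loose: a modest shift toward a higher number, with no change beyond the scatter also quite possible. The expected size is a 1.5-fold higher number from compound 1 to compound 3 (0.19 log units; within the scatter) on this estimate. For compound 3 the estimated value is 22000 nM, with an expected range from 7000 nM to 60000 nM.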

Compound 3, half-maximal cytotoxic concentration: > 67000 nM
Compound 3 gave a limit, no number; the forecaster's own chance of this, stated with the estimate: 35%; middle value at least 3.0-fold (0.48 log units) from the limit.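

In this assay, methyl in place of formyl gives an at least 4.7-fold higher number from compound 1 to compound 3 (0.67 log units; beyond the scatter) at the position meta to two methyl groups and para to a large group, the first sign that this place in the series affects the read-out. Compound 3 reads > 67000 nM as a limit of the assay, not a number, so the step has a known lower bound and no known size: the limit of > 67000 nM in this assay, at which 1 of the 3 values shown sits. Within the data shown here, compound 1, the formyl compound, remains the only one with a true number, 14200 nM in this assay.

From the compounds shown here alone, whether other groups at this place, such as an amine, a carboxylic acid or a longer chain, would read like formyl or like methyl stays open. Compound 2 differs from compound 1 and compound 3 in more than one place, so it does not help to settle this.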